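A few compounds are considered here, and "the series" means these few. Any claim that something is new, unique, unknown or untested is made for them only; others in the source may bear on it.

Measured so far:
compound 1, `COc1ccc(-c2cc3ccccc3nc2/C=C/C(=O)c2cccs2)cc1`: 410 nM in a functional assay on MDA-MB-231 cells (Homo sapiens) for antiproliferative activity, read by XTT assay, with a stated time of 72 h; a lower number here means a stronger inhibitor, a higher number a weaker inhibitor
compound 2, `COc1ccc(-c2cc3ccccc3nc2/C=C/C(=O)c2ccccn2)cc1`: 740 nM in this assay

Going by the values given here, compound 2 carries the highest of the two numbers; its only neighbour is compound 1, and the step of a 1.8-fold higher number from compound 1 to compound 2 (0.26 log units; within the scatter) lies within the scatter. Compound 3, `COc1ccc(-c2cc3ccccc3nc2/C=C/C(=O)c2cnc(N)nc2C)cc1`, differs from compound 2 by 2-amino-4-methylpyrimidin-5-yl in place of pyridin-2-yl on a carbonyl carbon. Among the compounds with values here, the one measured step at this carbonyl carbon, a 1.8-fold higher number from compound 1 to compound 2 (0.26 log units; within the scatter), shows that swapping the aryl group there moved the number little. Within the data shown here, the change to compound 3 is larger than that swap, and no measured pair covers an amino or methyl substituent here, so for compound 3 a step of about a 1.4-fold higher number from compound 2 to compound 3 (0.13 log units; within the scatter) in this assay is expected, likely still within the scatter. The estimate for compound 3 is 1000 nM, in the range 350 nM to 3000 nM.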

Compound 3, half-maximal inhibitory concentration: > 10000 nM
Compound 3 was reported as a limit; the forecaster's own chance of this, stated with the estimate: 5%; middle value at least 10-fold (1.00 log units) away from the limit.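

Swapping aryl groups on this carbonyl carbon is not always harmless in this assay: 2-amino-4-methylpyrimidin-5-yl gives an at least 13-fold higher number from compound 2 to compound 3 (1.13 log units; beyond the scatter) and an at least 24-fold higher number from compound 1 to compound 3 (1.38 log units; beyond the scatter), whereas the earlier swap between thiophen-2-yl and pyridin-2-yl stayed within the scatter. The value of compound 3 is a limit of the assay and not a number: the limit of > 10000 nM in this assay, at which 1 of the 3 values shown sits.

Which part of the change matters remains open, as the amino group, the methyl group and the added ring nitrogen atoms all enter together. A 2-aminopyrimidin-5-yl or a 4-methylpyrimidin-5-yl group at this carbonyl carbon would separate them.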